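The source may report more compounds than this note shows. Statements on the series, on what has been measured and on what is new or still open speak of the compounds shown alone.

In a functional assay on MCF7 cells (Homo sapiens) for cytotoxicity, read by MTT assay, with a stated time of 72 h (on this read-out higher numbers stand for weaker inhibition and lower numbers for stronger inhibition), compound 1 (`CN(C)CCCCCn1c2c(c3ccccc31)C(=O)c1c[n+]([O-])c3ccccc3c1C2=O`) gives 200 nM, compound 2 (`O=C1c2c[n+]([O-])c3ccccc3c2C(=O)c2c1c1ccccc1n2Cc1cn(CC(O)CO)nn1`) gives 1110 nM and compound 3 (`CN(C)CCCCn1c2c(c3ccccc31)C(=O)c1c[n+]([O-])c3ccccc3c1C2=O`) gives 220 nM. Compound 3 therefore sits with compound 1, at a 1.1-fold higher number from compound 1 to compound 3 (0.04 log units; within the scatter), and apart from compound 2, at a 5.0-fold lower number from compound 2 to compound 3 (0.70 log units; beyond the scatter). Compound 4 (`O=C1c2c[n+]([O-])c3ccccc3c2C(=O)c2c1c1ccccc1n2CCCN1CCC(O)CC1`) carries 4-hydroxypiperidin-1-yl in place of (dimethylamino)methyl, on a saturated chain carbon, three bonds along the chain from an aromatic nitrogen: 4-hydroxypiperidin-1-yl in place of (dimethylamino)methyl on a saturated chain carbon, three bonds along the chain from an aromatic nitrogen. Within the data shown here, two steps bear on this change. Dimethylamino in place of (dimethylamino)methyl gave a 1.1-fold higher number from compound 1 to compound 3 (0.04 log units; within the scatter), while the triazole group of compound 2 in place of 4-(dimethylamino)butyl gave a 5.6-fold higher number from compound 1 to compound 2 (0.74 log units; beyond the scatter). Neither step tests this ring directly, so a small move towards a higher number is expected in this assay, smaller than the compound 2 step. The expected step is a 1.6-fold higher number from compound 3 to compound 4 (0.20 log units; within the scatter). For compound 4 the estimated value is 350 nM, with an expected range of 130 nM to 900 nM.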

Compound 4, half-maximal inhibitory concentration: 190 nM
The estimate for compound 4 lay 1.8-fold (0.27 log units) above the measured number, and the stated range covers the measured number.
By their numbers in this assay, from the lowest: compounds 4, 1 and 3 (each within the scatter of the next); then compound 2.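

In this assay, 4-hydroxypiperidin-1-yl at the end of the chain, three bonds along from an aromatic nitrogen, gives a 1.2-fold lower number from compound 3 to compound 4 (0.06 log units; within the scatter) and a 1.1-fold lower number from compound 1 to compound 4 (0.02 log units; within the scatter), so this ring with its hydrogen-bond donor is tolerated here. Compound 2 still stands apart, with a 5.8-fold lower number from compound 2 to compound 4 (0.77 log units; beyond the scatter). Nothing at hand gives a cause for these numbers.

On these data alone, whether the ring or its hydroxyl carries any weight stays open: plain piperidine and morpholine on the same chain would separate the two. A carboxylic acid at this chain end is also an open case.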